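A few compounds are considered here, and "the series" means these few. Any claim that something is new, unique, unknown or untested is made for them only; others in the source may bear on it.

Working notes on the series. Compound 1 `Cc1nc2nc(-c3ccccc3)cc(C(F)(F)F)c2c(=O)n1Cc1cn(CCC(F)(F)C(F)(F)C(F)(F)C(F)(F)C(F)(F)C(F)(F)F)nn1` and compound 3 `CCc1nc2nc(-c3ccccc3)cc(C(F)(F)F)c2c(=O)n1Cc1cn(CCC(F)(F)C(F)(F)C(F)(F)C(F)(F)C(F)(F)C(F)(F)F)nn1` carry the same perfluorinated chain; they differ by methyl in place of hydrogen on a saturated chain carbon bound to an aromatic carbon. In a functional assay on U-937 cells (Homo sapiens) for cytotoxicity, read by MTT assay, with a stated time of 24 h (a lower number here means a stronger inhibitor, a higher number a weaker inhibitor), compound 1 gives > 200 ug/mL, which is a limit of the assay and not a number. Compound 3 likewise gives > 200 ug/mL, again a limit. The step that the two limits leave unreadable from compound 1 to compound 3 therefore cannot be sized, because both values sit at the limit of > 200 ug/mL in this assay, at which 2 of the 3 values shown sit. Compound 2 `CCCCCCCCCCn1cc(Cn2c(C)nc3nc(-c4ccccc4)cc(C(F)(F)F)c3c2=O)nn1` carries a decyl chain instead; the difference between the cores of compound 1 and compound 2 is not broken down here. In this assay, for the measured compounds named here, compound 2 gives 6.2 ug/mL, the only number in the set. Compound 4 `CCCCCCCCCCn1cc(Cn2c(CC)nc3nc(-c4ccccc4)cc(C(F)(F)F)c3c2=O)nn1` differs from compound 2 by methyl in place of hydrogen on a saturated chain carbon bound to an aromatic carbon, the same kind of change as between compound 1 and compound 3, at the same place. No readable size exists for that change, so compound 4 is expected to stay near compound 2, with a step of about a 1.1-fold higher number from compound 2 to compound 4 (0.05 log units; within the scatter), giving an estimated value of 7 ug/mL for compound 4.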

Compound 4, half-maximal inhibitory concentration: 17.8 ug/mL
Compound 4: the middle estimate sits 2.5-fold (0.41 log units) below what was measured, within the range that was stated.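

In this assay, the change from methyl to ethyl on the decyl series gives a 2.9-fold higher number from compound 2 to compound 4 (0.46 log units; beyond the scatter), which is a modest step towards a weaker inhibitor. The same change on the perfluorinated chain cannot be read, because both values there are limits of the assay and not numbers: the limit of > 200 ug/mL in this assay, at which 2 of the 4 values shown sit.

The series therefore holds a single readable instance of this change, which shows neither that the step carries from one core to another nor that it fails to. Left open is how a propyl group in place of the ethyl of compound 4 would read, and whether the step would persist with an octyl chain in place of the decyl chain.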